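Benzyloxycarbonyl to allyloxycarbonyl: working notes

This account rests on a few compounds, and the source may have more. Where it says the series, first, only, none or still open, it means among the compounds named here.

Measured in a functional assay on HCT-116 cells (Homo sapiens) for inhibition, read by MTT assay, with a stated time of 96 h (a higher number here means a weaker inhibitor of growth, a lower number a stronger inhibitor of growth), so far:
- compound 1 `O=C(NCCCCCCSSCCCCCCNC(=O)c1cc(-c2ccncc2)n[nH]1)c1cc(-c2ccncc2)n[nH]1` gives 8930 nM
- compound 2 `O=C(OCc1ccccc1)SCCCCCCNC(=O)c1cc(-c2ccncc2)n[nH]1` gives 18200 nM
- compound 3 `O=C(NCCCCCCS)c1cc(-c2ccc(-c3ccccc3)cc2)n[nH]1` gives > 50000 nM as a limit of the assay

Compound 2 at 18200 nM holds the higher of the two numeric values, and compound 1 at 8930 nM lies lower by a gap beyond the scatter. Compound 4 `C=CCOC(=O)SCCCCCCNC(=O)c1cc(-c2ccncc2)n[nH]1` differs from compound 2 vinyl in place of phenyl on a saturated chain carbon bound to an oxygen next to a carbonyl group as vinyl in place of phenyl on a saturated chain carbon bound to an oxygen next to a carbonyl group. For the measured compounds named here, no measured pair isolates this change. In this assay the expected step of a 1.2-fold lower number from compound 2 to compound 4 (0.08 log units; within the scatter) is small and stays within the scatter. The estimate for compound 4 is 15000 nM with an expected range of 7000 nM to 40000 nM for the coming measurement.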

Compound 4, concentration for 50% growth inhibition: 32900 nM
Beside the measured number, compound 4's estimate is 2.2-fold (0.34 log units) below it; the range from low to high includes it.
By their numbers in this assay, from the lowest: compound 1; then compounds 2 and 4 (each within the scatter of the next). At a limit, above all of these: compound 3.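

In this assay, for the compounds shown here, the step at this position reads a 1.8-fold higher number from compound 2 to compound 4 (0.26 log units; within the scatter), the first measured pair to isolate a change here. Vinyl in place of phenyl on a saturated chain carbon bound to an oxygen next to a carbonyl group removes the six-membered aromatic ring, yet in this one pair the number stays within the scatter, so that ring is not needed to hold this level. Nothing measured in this series accounts for the size of the step.

Open, from the compounds shown here alone, is whether a saturated ethyl, a longer chain or an amine-bearing chain at this position would give a similar number.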